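Swapping the aryl hydrazone on a shared urea core

This account rests on a few compounds, and the source may have more. Where it says the series, first, only, none or still open, it means among the compounds named here.

Compound 1 `CN(C)CCn1cnnc1-c1cc(Oc2ccc(NC(=O)N/N=C/c3c[nH]c4ccccc34)cc2F)ccn1`: 1630 nM
Compound 2 `CN(C)CCn1cnnc1-c1cc(Oc2ccc(NC(=O)N/N=C/c3ccc(F)cc3Cl)cc2F)ccn1`: 720 nM
Compound 3 `CN(C)CCn1cnnc1-c1cc(Oc2ccc(NC(=O)N/N=C/c3ccc(O)cc3O)cc2F)ccn1`: 11300 nM

In a functional assay on NCI-H460 cells (Homo sapiens) for cytotoxicity, read by MTT assay, with a stated time of 72 h (on this read-out lower numbers stand for stronger inhibition and higher numbers for weaker inhibition), compound 3 stands highest of the three, with the step of a 6.9-fold higher number from compound 1 to compound 3 (0.84 log units; beyond the scatter) and the step of a 16-fold higher number from compound 2 to compound 3 (1.20 log units; beyond the scatter) both beyond the scatter. Compound 4 `Cc1cc(/C=N/NC(=O)Nc2ccc(Oc3ccnc(-c4nncn4CCN(C)C)c3)c(F)c2)cc(C)c1O` differs from compound 3 by 4-hydroxy-3,5-dimethylphenyl in place of 2,4-dihydroxyphenyl on a carbon with a double bond to nitrogen. Both measured steps into compound 3 bear on this change: each introduced the 2,4-dihydroxyphenyl in place of another aryl group and raised the number, so leaving that group is expected to lower it, though the new group is itself untested. For compound 4 a modest downward step a 3.2-fold lower number from compound 3 to compound 4 (0.51 log units; beyond the scatter) is therefore expected. Compound 4 is estimated at 3500 nM, between 1000 nM and 12000 nM.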

Compound 4, half-maximal inhibitory concentration: 2010 nM
The estimate for compound 4 lay 1.7-fold (0.24 log units) above the measured number; low and high end bracket the measured number.
By their numbers in this assay, from the lowest: compound 2; then compounds 1 and 4 (each within the scatter of the next); then compound 3.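

In this assay the change to 4-hydroxy-3,5-dimethylphenyl gives a 5.6-fold lower number from compound 3 to compound 4 (0.75 log units; beyond the scatter) on this carbon, so an aryl group that keeps a hydroxy group need not stand as high as 2,4-dihydroxyphenyl. The step of a 1.2-fold higher number from compound 1 to compound 4 (0.09 log units; within the scatter) places the new group level with 1H-indol-3-yl. Against 2-chloro-4-fluorophenyl, however, the result is a 2.8-fold higher number from compound 2 to compound 4 (0.45 log units; beyond the scatter) and the halogenated group keeps the lowest number. On these data alone, whether an amine or a carboxylic acid on this aryl ring would fit the same order remains open. Nothing available accounts for these differences.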